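Trifluoromethyl on the phenylsulfonyl of compound 2

The compounds below may be only part of what the source reports. "The series", "measured", "known", "first", "only" and "open" are said of these compounds alone.

Measured so far:
compound 1, `Nc1nc2c(c(=O)n(CC3CC3)c(=O)n2CC2CC2)n1Cc1ccccc1`, 27%
compound 2, `Nc1nc2c(c(=O)n(CC3CC3)c(=O)n2CC2CC2)n1S(=O)(=O)c1ccccc1`, 13%

In an assay on isolated protein with dual specificity calcium/calmodulin-dependent 3',5'-cyclic nucleotide phosphodiesterase 1B (Bos taurus) as the target, tested at 100 uM (a higher number here means more inhibition at the concentration tested (going by the name of the read-out), a lower number less inhibition), compound 1 gives 27%. Compound 2, in which a phenylsulfonyl replaces the benzyl on an aromatic nitrogen, gives 13% in this assay, the lowest of the two numbers; the step of a number 14 percentage points lower from compound 1 to compound 2 (beyond the scatter) is modest but beyond the scatter.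

Compound 3, `Nc1nc2c(c(=O)n(CC3CC3)c(=O)n2CC2CC2)n1S(=O)(=O)c1ccc(C(F)(F)F)cc1`, is not yet measured. It differs from compound 2 by trifluoromethyl in place of hydrogen on an aromatic carbon. Among the measured compounds shown here, neither measured step concerns a change on the phenylsulfonyl ring itself: the only step recorded, a number 14 percentage points lower from compound 1 to compound 2 (beyond the scatter), exchanges the whole group on the aromatic nitrogen, so nothing measured bears directly on adding a trifluoromethyl here. With no guide from the data, the step of a number 2 percentage points higher from compound 2 to compound 3 (within the scatter) is expected to stay within the scatter. Compound 3 is therefore estimated at 15% in this assay, with a range from 3% to 32%.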

Compound 3, a percentage reported as inhibition, at one concentration (the size of the read-out at that concentration, not a potency): 0%
The estimate for compound 3 lay 15 percentage points above the measured number; the measured number lies below the stated range.
By their numbers in this assay, from the lowest: compound 3; then compound 2; then compound 1.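

Read in this assay, the change gives a number 13 percentage points lower from compound 2 to compound 3 (beyond the scatter) and is the first reading of a change on the phenylsulfonyl ring itself, which shows that the number responds to what is carried on this ring and not only to the group exchanged on the aromatic nitrogen. The step is of modest size, as is a number 14 percentage points lower from compound 1 to compound 2 (beyond the scatter) on the same shared core, so a single trifluoromethyl para to a large group matters here about as much as that whole-group exchange. Nothing available on these compounds gives a measured basis for explaining the drop.

The compounds shown do not tell whether the drop belongs to trifluoromethyl in particular or would follow from any group at this place on the ring, since a methyl, a methoxy, an amine or a carboxylic acid on the same aromatic carbon does not appear among them. They also leave open whether a trifluoromethyl on the phenyl of the benzyl group of compound 1 would lower the number in the same way.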